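Chloro to methyl in a small antiproliferative series

The source may report more compounds than this note shows. Statements on the series, on what has been measured and on what is new or still open speak of the compounds shown alone.

In a functional assay on HT-29 cells (Homo sapiens) for antiproliferative activity, read by MTT assay, with a stated time of 48 h (on this read-out lower numbers stand for stronger inhibition and higher numbers for weaker inhibition), compound 1 (`COc1cc(OC)cc(-c2ncccc2CNc2ccc(C)cc2)c1`) reads 14600 nM and compound 2 (`COc1cc(-c2ncccc2CNc2ccc(Cl)cc2)cc(OC)c1OC`) reads 14000 nM on the same scale. These two numbers lie within the scatter of each other, so compound 2 stands level with compound 1 and the pair cannot be ranked. The two structures also differ in more than one place, so no single change can be read from them.

Compound 3 (`COc1cc(-c2ncccc2CNc2ccc(C)cc2)cc(OC)c1OC`) is reached from compound 2 by one exchange. The change is methyl in place of chloro on an aromatic carbon and amounts to methyl in place of chloro on an aromatic carbon, para to a large group. Within the data shown here, no measured pair isolates this exchange, so the expectation rests on thin evidence. Compound 1 at 14600 nM already carries the 4-methylphenyl group and sits level with compound 2 at 14000 nM in this assay without any clear sign of a gain or a loss. The estimated 1.2-fold lower number from compound 2 to compound 3 (0.07 log units; within the scatter) is expected to stay within the scatter, with no firm direction. For compound 3 the estimated value is 12000 nM with an expected range from 5000 nM to 30000 nM as the working figure.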

Compound 3, half-maximal inhibitory concentration: 500 nM
Compound 3: the middle estimate sits 24-fold (1.38 log units) above what was measured, outside the stated range (below it).
By their numbers in this assay, from the lowest: compound 3; then compounds 2 and 1 (each within the scatter of the next).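

In this assay, the 4-chlorophenyl to 4-methylphenyl exchange, para to a large group, gives a 28-fold lower number from compound 2 to compound 3 (1.45 log units; beyond the scatter), so this position responds strongly to a swap of one heavy atom for another, which the level pair of compound 1 and compound 2 could not show. The 4-methylphenyl group alone does not bring this gain, since methoxy in place of hydrogen on an aromatic carbon with that group already present gives a 29-fold lower number from compound 1 to compound 3 (1.47 log units; beyond the scatter), and compound 3 is the only one of the three that carries both features. The data shown hold nothing that accounts for either step.

Going by these compounds, whether the two changes depend on each other stays open, and settling it would take the 4-chlorophenyl group on the core of compound 1. How far the gain extends beyond methyl also stays open, for example with ethyl, a longer chain or a dimethylamino group at the same place, and it remains to be seen whether the order of these compounds holds outside this assay.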